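From an aryl group to an arylamino group

This account rests on a few compounds, and the source may have more. Where it says the series, first, only, none or still open, it means among the compounds named here.

Compound 1 `COc1ccccc1-c1c(C(=O)c2cc(OC)c(OC)c(OC)c2)sc2ccccc12` gives 5000 nM
Compound 2 `COc1ccc(-c2c(C(=O)c3cc(OC)c(OC)c(OC)c3)sc3ccccc23)c(OC)c1` gives 3900 nM
Compound 3 `COc1cc(C(=O)c2sc3ccccc3c2Nc2ccc(C)cc2)cc(OC)c1OC` gives 3500 nM

All three values come from a functional assay on HeLa cells (Homo sapiens) for antiproliferative activity, read by MTT assay, with a stated time of 72 h (on this read-out lower numbers stand for stronger inhibition and higher numbers for weaker inhibition), and lie within the scatter of one another. Compound 2 therefore has no real separation from its neighbours, as shown by a 1.3-fold lower number from compound 1 to compound 2 (0.11 log units; within the scatter) and by a 1.1-fold lower number from compound 2 to compound 3 (0.05 log units; within the scatter) in the same read-out.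

Compound 4 `CCOc1ccc(Nc2c(C(=O)c3cc(OC)c(OC)c(OC)c3)sc3ccccc23)cc1` has not yet been measured. It carries (4-ethoxyphenyl)amino in place of 2,4-dimethoxyphenyl on an aromatic carbon.

The closest guide is compound 3, which also has an arylamino group in place of 2,4-dimethoxyphenyl, giving a 1.1-fold lower number from compound 2 to compound 3 (0.05 log units; within the scatter) as its step. The exchange in a 1.4-fold lower number from compound 1 to compound 3 (0.15 log units; within the scatter) points the same way. Neither step exceeds the scatter, so none beyond it is expected here. Within the data shown here, no measured compound carries an ethoxy group, which leaves the range wide.

The estimated change is a 1.3-fold lower number from compound 2 to compound 4 (0.11 log units; within the scatter) and would stay small.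

Compound 4 is expected at about 3000 nM with an estimated range from 400 nM to 8000 nM in this assay when tested.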

Compound 4, half-maximal inhibitory concentration: 700 nM
Compound 4: middle estimate off by 4.3-fold (0.63 log units), on the high side; the range from low to high includes it.
By their numbers in this assay, from the lowest: compound 4; then compounds 3, 2 and 1 (each within the scatter of the next).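

Among the earlier compounds, no exchange at this position moved the number beyond the scatter, not even the change from an aryl to an arylamino group. In this assay the ethoxy group brings the first clear change, with a 5.0-fold lower number from compound 3 to compound 4 (0.70 log units; beyond the scatter) when ethoxy replaces methyl on the arylamino group, so the arylamino group alone does not account for the result. The steps of a 5.6-fold lower number from compound 2 to compound 4 (0.75 log units; beyond the scatter) and a 7.1-fold lower number from compound 1 to compound 4 (0.85 log units; beyond the scatter) are also beyond the scatter, but each changes the whole group at this position, so they cannot single out the ethoxy group. No measurement here explains why this exchange matters.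

The compounds shown leave open whether a methoxy group or a longer chain such as propoxy or butoxy in place of the ethoxy would lower the number further. They also leave open whether a morpholine or a carboxylic acid would be tolerated there.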